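The source may hold more compounds than are shown below. What is called first, only, known or untested is meant among the compounds shown, and "the series" means these compounds.

Of the compounds shown here, three have so far been measured in a functional assay on the whole organism (Tail, strain ICR) with Mus musculus as the target, in the tail flick test, with a stated time of 90 min, at a dose of 25 umol/kg by the oral route; a higher number here means a stronger effect of the compound at the dose given, a lower number a weaker effect. Compound 1 `O=C(CN(c1ncnc2c1ncn2C1CCCCO1)C1CC1)N[C@@H](CCC(=O)OCc1ccccc1)C(=O)OCc1ccccc1` gives 25.2%. Compound 2 `O=C(CN(c1nc(Cl)nc2[nH]cnc12)C1CC1)N[C@@H](CCC(=O)OCc1ccccc1)C(=O)OCc1ccccc1` gives 50%, and compound 3 `O=C(O)CC[C@H](NC(=O)CN(c1nc(Cl)nc2[nH]cnc12)C1CC1)C(=O)O` gives 44.7%. Compound 1 thus stands lowest of the three: compound 3 is its nearest neighbour, with a reading beyond the scatter above it, and compound 2 is furthest, also beyond the scatter. The readings of compound 2 and compound 3 lie within the scatter of each other, so nothing can be said about an order between those two.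

The unmeasured compound 4 `NC(=O)C[C@H](NC(=O)CN(c1ncnc2c1ncn2C1CCCCO1)C1CC1)C(=O)OCc1ccccc1` keeps the core of compound 1 and alters one side chain: carbamoyl in place of (benzyloxycarbonyl)methyl on a saturated chain carbon, two bonds along the chain from an amide-type nitrogen and a carbonyl carbon. Among the measured compounds shown here, no pair of measured compounds shows this change, so its effect cannot be read from the data. The step of a number 4.8 percentage points higher from compound 1 to compound 4 (within the scatter) is expected to be small, within the scatter, with no clear direction. Compound 4 is therefore estimated to give 30% in this assay, with a likely range from 12% to 50%.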

Compound 4, a percentage reported as activity, at one dose (the size of the read-out at that dose, not a potency): 35%
Beside the measured number, compound 4's estimate is 5 percentage points below it; the measured number falls inside the stated range.
By their numbers in this assay, from the lowest: compounds 1, 4, 3 and 2 (each within the scatter of the next, the first and the last beyond it).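

At this position of the side chain, on a saturated chain carbon, two bonds along the chain from an amide-type nitrogen and a carbonyl carbon, carbamoyl in place of (benzyloxycarbonyl)methyl gives in this assay a number 9.8 percentage points higher from compound 1 to compound 4 (within the scatter). The change removes a six-membered aromatic ring and most of the group's heavy atoms, yet the read-out shows no clear shift, so on the core of compound 1 this large benzyl-bearing group is not shown to be needed for the effect at this dose. No measurement here explains this result.

Still open, on these data alone, is how a primary amine or a hydroxyl group at this carbon would read. This single step also cannot show whether carbamoyl would behave the same way on another core.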